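Swapping the phenyl group on the ring nitrogen: compound 2 to compound 3

The compounds below may be only part of what the source reports. "The series", "measured", "known", "first", "only" and "open" are said of these compounds alone.

In a physicochemical assay for solubility, read by turbidimetry, measured as kinetic solubility, at pH 7.4 (on this read-out higher numbers stand for higher solubility and lower numbers for lower solubility), compound 2 (`C#Cc1cccc(N2C(=O)CSC2c2cccc(C(=O)NCCCCc3ccccc3)c2)c1`) stands at 10000 nM and sits level with compound 1 (`COc1ccc(F)cc1N1C(=O)CSC1c1cccc(C(=O)NCCCCc2ccccc2)c1`), which gives 10000 nM as well. Compound 3 (`O=C(NCCCCc1ccccc1)c1cccc(C2SCC(=O)N2c2ccccc2F)c1`) carries 2-fluorophenyl in place of 3-ethynylphenyl on an amide-type nitrogen in a ring. Going by the values given here, only one measured step bears on this place (no change at the digits printed from compound 1 to compound 2 (within the scatter)), and it stayed within the scatter, which makes thin evidence. No move beyond the scatter is therefore expected in this assay, the estimated step being (no change at the digits printed from compound 2 to compound 3 (within the scatter)). The estimated value for compound 3 is 10000 nM with a range of 5000 nM to 15000 nM on this reading.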

Compound 3, solubility: 10000 nM
The estimate for compound 3 equals the measured number at the digits printed, within the range that was stated.
By their numbers in this assay, from the lowest: compounds 1, 2 and 3 (each within the scatter of the next).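

In this assay, 2-fluorophenyl on the amide-type nitrogen in a ring gives no change at the digits printed from compound 2 to compound 3 (within the scatter), and against the 5-fluoro-2-methoxyphenyl group it gives no change at the digits printed from compound 1 to compound 3 (within the scatter). The three phenyl groups at this place now read alike, and that set includes one with neither a methoxy group nor a triple bond outside aromatic rings.

Still open, on these data alone, is whether an amine or a carboxylic acid on this phenyl ring would move the reading beyond the scatter. No supporting data accompany these readings to account for their sameness.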